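Trifluoromethoxy for trifluoromethyl: cytotoxicity step

The compounds below may be only part of what the source reports. "The series", "measured", "known", "first", "only" and "open" are said of these compounds alone.

Compound 1 `Cc1cc(NC(=O)Nc2ccc([N+](=O)[O-])c(C(F)(F)F)c2)c2ccccc2n1` reaches only the limit > 25000 nM in an ADME assay on HEK293 cells (Homo sapiens) for cytotoxicity, with a stated time of 72 h (a higher number here means that more compound is needed for the effect, a lower number that less compound is needed), a limit of the assay rather than a number. Among the measured compounds shown here, compound 2 `Cc1cc(NC(=O)Nc2cccc(C(F)(F)F)c2)c2ccccc2n1` gives 16000 nM in this assay, the single number in this assay. The other value shown, that of compound 1, is a limit (the limit of > 25000 nM in this assay, at which 1 of the 2 values shown sits). For the measured compounds named here, the step of an at least 1.5-fold lower number from compound 1 to compound 2 (0.19 log units; that floor lies within the scatter) is the only measured step. Compound 3 `Cc1cc(NC(=O)Nc2cccc(OC(F)(F)F)c2)c2ccccc2n1` differs from compound 2 by trifluoromethoxy in place of trifluoromethyl on an aromatic carbon. Going by the values given here, no measured step bears on this exchange, so no shift beyond the scatter is expected. Compound 3 is estimated at 16000 nM, with a range of 8000 nM to 32000 nM, meaning an expected step of no change at the digits printed from compound 2 to compound 3 (within the scatter).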

Compound 3, half-maximal effective concentration: 22000 nM
Estimate against measurement, compound 3: 1.4-fold (0.14 log units) below; measured number inside the range.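

In this assay, among the compounds shown here, the exchange of trifluoromethyl for trifluoromethoxy on this aromatic carbon, meta to a large group, gives a 1.4-fold higher number from compound 2 to compound 3 (0.14 log units; within the scatter) and is the first measured step at this position. The extra oxygen, with its one hydrogen-bond acceptor, therefore does not separate compound 2 from compound 3 in this read-out.

Going by these compounds, whether an amine, a carboxylic acid or a longer alkoxy chain at this position would move the number beyond the scatter remains open, as does the same exchange with the nitro group of compound 1 present. No measured finding at hand bears on the cause of this step.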